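The source may hold more compounds than are shown below. What is called first, only, known or untested is meant among the compounds shown, and "the series" means these compounds.

Values in a functional assay on A549 cells (Homo sapiens) for antiproliferative activity, read by MTT assay, with a stated time of 72 h; a lower number here means a stronger inhibitor, a higher number a weaker inhibitor:

compound 1 `COc1cc(-n2cnc3ccc(-c4cc(F)ccc4F)cc32)cc(OC)c1OC`: 7940 nM
compound 2 `COc1cc(-n2cnc3ccc(-c4cccc(Cl)c4)cc32)cc(OC)c1OC`: 7050 nM
compound 3 `COc1cc(-c2ccc3ncn(-c4cc(OC)c(OC)c(OC)c4)c3c2)cc(OC)c1OC`: a limit of the assay, > 10000 nM

Compound 2 gives the lowest of the two numbers shown, and its nearest neighbour is compound 1, with the step of a 1.1-fold lower number from compound 1 to compound 2 (0.05 log units; within the scatter) within the scatter. Compound 3 reports only a limit (the limit of > 10000 nM in this assay, at which 1 of the 3 values shown sits). Compound 4 `COc1cccc(-c2ccc3ncn(-c4cc(OC)c(OC)c(OC)c4)c3c2)c1` differs from compound 2 by methoxy in place of chloro on an aromatic carbon. Within the data shown here, the single measured step bearing on the pendant ring, a 1.1-fold lower number from compound 1 to compound 2 (0.05 log units; within the scatter), swaps one halogen pattern for another and stays within the scatter; no measured step exchanges chloro for methoxy. On that basis the step from compound 2 to compound 4 is expected to be small, a 1.3-fold higher number from compound 2 to compound 4 (0.11 log units; within the scatter), with a slight lean toward a higher number. Compound 4 is therefore estimated at 9000 nM, between 4000 nM and 20000 nM.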

Compound 4, half-maximal inhibitory concentration: 3180 nM
The estimate for compound 4 lay 2.8-fold (0.45 log units) above the measured number; the whole stated range lies above it.
By their numbers in this assay, from the lowest: compound 4; then compounds 2 and 1 (each within the scatter of the next). At a limit, above all of these: compound 3.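

Among these compounds, at this position, on the pendant ring and meta to a large group, the exchange between halogen patterns stayed within the scatter, whereas 3-methoxyphenyl gives the first change beyond it: in this assay the steps read a 2.2-fold lower number from compound 2 to compound 4 (0.35 log units; beyond the scatter) and a 2.5-fold lower number from compound 1 to compound 4 (0.40 log units; beyond the scatter) for the two halogenated rings. The position therefore responds to the choice of substituent, though only modestly so far. Nothing measured here accounts for this difference.

Open, as far as these compounds go, is whether a hydroxyl, an amine or a longer alkoxy chain at this place would extend the step. Also open, from the compounds shown here alone, is whether methoxy elsewhere on the ring would give a similar one.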